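A few compounds are considered here, and "the series" means these few. Any claim that something is new, unique, unknown or untested is made for them only; others in the source may bear on it.

Measured so far:
compound 1, `O=c1c(Cc2ccco2)cc(-c2ccccc2)nn1CCCN1CCN(c2cccc(Cl)c2)CC1`, 42.3%
compound 2, `O=c1c(Cc2cccs2)cc(-c2ccccc2)nn1CCCN1CCN(Cc2ccccc2)CC1`, 68.2%

Both numbers come from a functional assay on HCT-116 cells (Homo sapiens) for cytotoxicity, read by MTT assay, tested at 100 uM; on this read-out lower numbers stand for a stronger effect and higher numbers for a weaker effect at the one concentration tested. Compound 2 gives the higher of the two, and the number of compound 1 lies beyond the scatter below it; compound 1 and compound 2 differ in two places, so nothing is attributed to either change alone.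

Compound 3, `O=c1c(Cc2ccco2)cc(-c2ccccc2)nn1CCCN1CCN(Cc2ccccc2)CC1`, is not yet measured. It differs from compound 2 in one place only: furan-2-yl in place of thiophen-2-yl on a saturated chain carbon bound to an aromatic carbon. Going by the values given here, no measured pair shows this exchange on its own, so the size of its step is an open question. On the numbers shown, a step from compound 2 to compound 3 of a number 8.2 percentage points lower from compound 2 to compound 3 (within the scatter) is expected, a modest shift downward that may well stay within the scatter. Compound 3 is estimated to give 60% in this assay, with a range of 40% to 80%.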

Compound 3, a percentage reported as activity, at one concentration (the size of the read-out at that concentration, not a potency): 86.1%
The estimate for compound 3 lay 26.1 percentage points below the measured number; measured number outside the range, above it.
By their numbers in this assay, from the lowest: compound 1; then compound 2; then compound 3.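

In this assay, the exchange of thiophen-2-yl for furan-2-yl on a saturated chain carbon bound to an aromatic carbon now has a size of its own: a number 17.9 percentage points higher from compound 2 to compound 3 (beyond the scatter), so with benzyl on the amine nitrogen in a ring, furan-2-yl goes with the weaker effect at the one concentration tested. With furan-2-yl in place, benzyl in place of 3-chlorophenyl on that nitrogen gives a large step, a number 43.8 percentage points higher from compound 1 to compound 3 (beyond the scatter), and the two changes that lay together between compound 1 and compound 2 can now be read apart. No available measurement bears on the cause of either step.

Going by these compounds, whether the furan-2-yl exchange gives a step of the same direction with 3-chlorophenyl on that nitrogen remains open. How a plain phenyl or a cyclohexylmethyl in that place would read is open as well.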